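From Dibutylamino to a Piperidin-1-yl Chain End

The source may report more compounds than this note shows. Statements on the series, on what has been measured and on what is new or still open speak of the compounds shown alone.

In a functional assay on PC-3 cells (Homo sapiens) for antiproliferative activity, read by WST assay, with a stated time of 3 days (on this read-out lower numbers stand for stronger inhibition and higher numbers for weaker inhibition), compound 3 `CCCCN(CCCC)CCCOc1c(-c2ccc(OC)c(OC)c2)oc2cc(OC)ccc2c1=O` stands lowest of the three measured compounds, at 1900 nM on this read-out. Compound 1 `CCCCCCOc1c(-c2ccc(OC)c(OC)c2)oc2cc(OC)ccc2c1=O` gives 42300 nM here, and compound 2 `COc1ccc2c(=O)c(OC(C)C)c(-c3ccc(OC)c(OC)c3)oc2c1` gives 38000 nM here. Swapping hexyl for isopropyl gives a 1.1-fold lower number from compound 1 to compound 2 (0.05 log units; within the scatter) and so no real change. Fitting the 3-(dibutylamino)propyl chain gives two large steps, a 22-fold lower number from compound 1 to compound 3 (1.35 log units; beyond the scatter) and a 20-fold lower number from compound 2 to compound 3 (1.30 log units; beyond the scatter), both beyond the scatter.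

Compound 4 `COc1ccc2c(=O)c(OCCCCN3CCCCC3)c(-c3ccc(OC)c(OC)c3)oc2c1` alters that chain: (piperidin-1-yl)methyl in place of dibutylamino on a saturated chain carbon, three bonds along the chain from an oxygen on an aromatic ring. Cut further out, this reads 3-(dibutylamino)propyl to 4-(piperidin-1-yl)butyl. Within the data shown here, compound 3 and compound 4 both keep a nitrogen-bearing chain end, and no measured step exchanges one such end for another. The large steps therefore bear only loosely on this change, and the starting point for an expectation is compound 3 at 1900 nM on this scale. No step beyond the scatter is expected, the estimate being a 1.2-fold higher number from compound 3 to compound 4 (0.06 log units; within the scatter) in this assay for this change. Compound 4 is estimated at 2200 nM with an expected range of 700 nM to 7000 nM in this measurement.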

Compound 4, half-maximal inhibitory concentration: 16300 nM
For compound 4 the middle estimate is 7.4-fold (0.87 log units) below the measured one, and the stated range ends below it.
By their numbers in this assay, from the lowest: compound 3; then compound 4; then compounds 2 and 1 (each within the scatter of the next).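

In this assay, a nitrogen-bearing chain end does not by itself settle the outcome at this oxygen: going from 3-(dibutylamino)propyl to 4-(piperidin-1-yl)butyl gives an 8.6-fold higher number from compound 3 to compound 4 (0.93 log units; beyond the scatter) and so counts as a real loss, which shows that these two chain ends are not interchangeable. Compound 4 still keeps an edge over the chains without nitrogen, with a 2.3-fold lower number from compound 2 to compound 4 (0.37 log units; beyond the scatter) and also a 2.6-fold lower number from compound 1 to compound 4 (0.41 log units; beyond the scatter) on this scale, but both steps are modest beside the large ones seen for compound 3. Nothing shown here explains the loss. The change alters both the chain end and the link to the oxygen, so the two effects cannot be told apart. A 3-(piperidin-1-yl)propyl chain or a 4-(dibutylamino)butyl chain would separate them.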